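The source may hold more compounds than are shown below. What is called first, only, known or untested is meant among the compounds shown, and "the series" means these compounds.

Of the compounds shown here, three have been measured in an assay on isolated protein for inhibition of histone deacetylase 4 (Homo sapiens), read by fluorescence; on this read-out lower numbers stand for stronger inhibition and higher numbers for weaker inhibition. Compound 1, `O=C(/C=C/c1ccc(/C=C/C(=O)c2ccc3ccccc3c2)o1)NO`, gives 4380 nM. Compound 2, `O=C(/C=C/c1ccc(/C=C/C(=O)c2cccc(Cl)c2)o1)NO`, gives 12900 nM. Compound 3, `O=C(NO)c1ccc(/C=C/c2ccccc2O)o1`, gives 74200 nM, the highest of the three numbers; its gap to compound 2 and its wider gap to compound 1 both lie beyond the scatter, so compound 3 is the weakest inhibitor of the set.

Compound 4, `COc1cccc(/C=C/c2ccc(C(=O)NO)o2)c1O`, differs from compound 3 in one place: methoxy in place of hydrogen on an aromatic carbon. The group enters on an aromatic carbon of a six-membered aromatic ring of carbon only, ortho to a hydroxy group and meta to a large group. Among the measured compounds shown here, no pair among the measured compounds shows this change, and compounds 1 and 2 are built differently from compound 3, so there is no measured step to lean on. Such a small addition is expected to move the number in this assay only modestly, if at all beyond the scatter, and the direction cannot be read from the compounds at hand. The expected number for compound 4 is 60000 nM, with a range from 20000 nM to 200000 nM. The step that this estimate means, a 1.2-fold lower number from compound 3 to compound 4 (0.09 log units; within the scatter), is expected to stay within the scatter.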

Compound 4, half-maximal inhibitory concentration: 42800 nM
The estimate for compound 4 lay 1.4-fold (0.15 log units) above the measured number, and the stated range covers the measured number.
By their numbers in this assay, from the lowest: compound 1; then compound 2; then compounds 4 and 3 (each within the scatter of the next).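

Methoxy in place of hydrogen on an aromatic carbon, ortho to a hydroxy group and meta to a large group, gives the only single-place comparison in the set, and in this assay it amounts to a 1.7-fold lower number from compound 3 to compound 4 (0.24 log units; within the scatter), a step within the scatter. Compound 3 and compound 4 therefore cannot be told apart on this read-out, which shows that this position accepts a methoxy group, with its 2 heavy atoms and 1 hydrogen-bond acceptor, without a change that can be resolved from the scatter. No measured information accompanies this result that would bear on its origin.

This single step leaves open whether a different group on the same carbon, such as an amine, a carboxylic acid or a longer chain like butoxy, would also leave the number within the scatter, or would move it in either direction. It also leaves open how much the neighbouring hydroxy group contributes, a question that a compound carrying methoxy or fluorine in place of that hydroxy group could address.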